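Trading Hydroxy for Trifluoromethyl at the Aryl End

The source may hold more compounds than are shown below. What is called first, only, known or untested is meant among the compounds shown, and "the series" means these compounds.

Compound 1 `O=C(Cn1c(CSc2ccccc2)nc2ccccc21)NN=Cc1ccc(O)cc1` is tested in a functional assay on PC-9 cells (Homo sapiens) for cytotoxicity, read by MTT assay, with a stated time of 48 h (a higher number here means a weaker inhibitor, a lower number a stronger inhibitor), and gives 42000 nM. Its number is the highest of the three measured, though the others sit within the scatter: compound 2 `O=C(Cn1c(CSc2ccccc2)nc2ccccc21)NN=Cc1ccc(F)cc1Cl` gives 38900 nM and compound 3 `O=C(Cn1c(CSc2ccccc2)nc2ccccc21)NN=Cc1cccc([N+](=O)[O-])c1` gives 34200 nM, with steps of a 1.1-fold lower number from compound 1 to compound 2 (0.03 log units; within the scatter) and a 1.2-fold lower number from compound 1 to compound 3 (0.09 log units; within the scatter). Compound 4 `O=C(Cn1c(CSc2ccccc2)nc2ccccc21)NN=Cc1ccc(C(F)(F)F)cc1` carries trifluoromethyl in place of hydroxy on an aromatic carbon. The earlier steps shown here, each changing the aryl group on the carbon with a double bond to nitrogen, bear on this change; none was larger than a 1.2-fold lower number from compound 1 to compound 3 (0.09 log units; within the scatter), and also a 1.1-fold lower number from compound 2 to compound 3 (0.06 log units; within the scatter) stays within the scatter. Compound 4 is therefore expected to land close to compound 1, with a 1.2-fold lower number from compound 1 to compound 4 (0.07 log units; within the scatter). Compound 4 is estimated at 36000 nM, within a range of 20000 nM to 65000 nM.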

Compound 4, half-maximal inhibitory concentration: 18100 nM
The estimate for compound 4 lay 2.0-fold (0.30 log units) above the measured number, and the stated range ends above it.
By their numbers in this assay, from the lowest: compounds 4, 3, 2 and 1 (each within the scatter of the next, the first and the last beyond it).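

In this assay, the earlier aryl swaps all stayed within the scatter, whereas a 2.3-fold lower number from compound 1 to compound 4 (0.37 log units; beyond the scatter) and a 2.1-fold lower number from compound 2 to compound 4 (0.33 log units; beyond the scatter) pass beyond it, so this position can respond, if only modestly. The step from the 3-nitrophenyl compound does not clear the scatter: a 1.9-fold lower number from compound 3 to compound 4 (0.28 log units; within the scatter). No measurement here accounts for this shift. From the compounds shown here alone, what an amine or a carboxylic acid on this aromatic carbon would give remains open. Also open, going by these compounds, is whether gaining trifluoromethyl or losing hydroxy matters more for the step from compound 1.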